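The source may report more compounds than this note shows. Statements on the series, on what has been measured and on what is new or still open speak of the compounds shown alone.

Series notes, shared core of compound 1 `CC/C(=C(/c1ccc(/C=C/C(=O)O)cc1)c1cc2ccccc2[nH]1)c1ccccc1`. In a functional assay on MCF7 cells (Homo sapiens) for inhibition (a lower number here means a stronger inhibitor, a higher number a weaker inhibitor), compound 1 gives 108 nM, the second highest of the three numbers measured. Compound 2 `CC/C(=C(/c1ccc(/C=C/C(=O)O)cc1)c1cc2ccccc2[nH]1)c1ccc(C(F)(F)F)cc1` carries trifluoromethyl in place of hydrogen on an aromatic carbon and in this assay gives 139 nM; the step of a 1.3-fold higher number from compound 1 to compound 2 (0.11 log units; within the scatter) stays within the scatter, so the two cannot be ordered. Compound 3 `CC/C(=C(/c1ccc(/C=C/C(=O)O)cc1)c1cc2ccccc2[nH]1)c1ccc(F)cc1Cl` in this assay gives 39 nM; the step of a 2.8-fold lower number from compound 1 to compound 3 (0.44 log units; beyond the scatter) is the one shift so far that clears the scatter, and a 3.6-fold lower number from compound 2 to compound 3 (0.55 log units; beyond the scatter) points the same way.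

Compound 4 `CC/C(=C(/c1ccc(/C=C/C(=O)O)cc1)c1cc2ccccc2[nH]1)c1ccc(Cl)cc1Cl` differs from compound 1 in one place: 2,4-dichlorophenyl in place of phenyl on a double-bonded chain carbon bound to a double-bonded chain carbon and a saturated chain carbon. Among the measured compounds shown here, the only measured step that bears on it is a 2.8-fold lower number from compound 1 to compound 3 (0.44 log units; beyond the scatter), where 2-chloro-4-fluorophenyl entered on the same double-bonded chain carbon. Nothing measured separates a second chlorine from a fluorine on that ring, so the expectation for compound 4 in this assay is a step of about that size, downward, namely a 2.4-fold lower number from compound 1 to compound 4 (0.38 log units; beyond the scatter). Compound 4 is therefore estimated at 45 nM in this assay, with a range of 20 nM to 110 nM; a result within the scatter of compound 1 would not be surprising either.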

Compound 4, half-maximal inhibitory concentration: 11 nM
Estimate against measurement, compound 4: 4.1-fold (0.61 log units) above; measured number outside the range, below it.
By their numbers in this assay, from the lowest: compound 4; then compound 3; then compounds 1 and 2 (each within the scatter of the next).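

In this assay, among the compounds shown here, the ring on the double-bonded chain carbon bound to a double-bonded chain carbon and a saturated chain carbon proves able to move the number much further than compounds 1 to 3 showed: 2,4-dichlorophenyl in place of phenyl gives a 9.8-fold lower number from compound 1 to compound 4 (0.99 log units; beyond the scatter), and 2,4-dichlorophenyl in place of 4-(trifluoromethyl)phenyl gives a 13-fold lower number from compound 2 to compound 4 (1.10 log units; beyond the scatter), the only step printed as large. For the compounds shown here, the identity of the halogen also counts at this position, which the earlier compounds could not show: chloro in place of fluoro on an aromatic carbon gives a 3.5-fold lower number from compound 3 to compound 4 (0.55 log units; beyond the scatter), a step beyond the scatter, so the two halogenated rings are not interchangeable here. No measurement available bears on the cause of these steps.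

Still open, from the compounds shown here alone, is whether a single chloro on the phenyl ring would account for part of this gain, or whether both halogens are needed, and whether bromo or methoxy in place of chloro would hold the number near that of compound 4 at 11 nM. Also open, going by these compounds, is how an amide in place of the carboxylic acid would behave with the 2,4-dichlorophenyl ring in place.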